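Notes on the step from compound 2 to compound 3

A few compounds are considered here, and "the series" means these few. Any claim that something is new, unique, unknown or untested is made for them only; others in the source may bear on it.

- Compound 1 (`CN(C)CCCCCn1c2c(c3ccccc31)C(=O)c1c[n+]([O-])c3ccccc3c1C2=O`) gives 470 nM in a functional assay on HCT-116 cells (Homo sapiens) for cytotoxicity, read by MTT assay, with a stated time of 72 h; on this read-out lower numbers stand for stronger inhibition and higher numbers for weaker inhibition
- Compound 2 (`O=C1c2c[n+]([O-])c3ccccc3c2C(=O)c2c1c1ccccc1n2Cc1cn([C@@H]2C[C@H](O)[C@@H](CO)O2)nn1`) gives 50 nM in this assay

Compound 2 has the lower of the two numbers, and the gap up to compound 1 lies beyond the scatter. The two measured compounds do not form a step that differs in one place, so the size of a single change is not shown by these data. Compound 3 (`O=C1c2c[n+]([O-])c3ccccc3c2C(=O)c2c1c1ccccc1n2Cc1cn(CC(O)CO)nn1`) carries 2,3-dihydroxypropyl in place of 4-hydroxy-5-(hydroxymethyl)oxolan-2-yl on an aromatic nitrogen. The expectation rests on compound 2 (50 nM) as its only close reference. In this assay a small rise in the number is expected, not beyond the scatter, as the estimated step (a 1.8-fold higher number from compound 2 to compound 3 (0.26 log units; within the scatter)) shows. For compound 3 the expected value is 90 nM, with an estimated range from 30 nM to 270 nM.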

Compound 3, half-maximal inhibitory concentration: 250 nM
Beside the measured number, compound 3's estimate is 2.8-fold (0.44 log units) below it, within the range that was stated.
By their numbers in this assay, from the lowest: compound 2; then compounds 3 and 1 (each within the scatter of the next).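

This position on the aromatic nitrogen of the five-membered aromatic ring with 3 nitrogen is not indifferent to the group it carries in this assay: 2,3-dihydroxypropyl in place of 4-hydroxy-5-(hydroxymethyl)oxolan-2-yl gives a 5.0-fold higher number from compound 2 to compound 3 (0.70 log units; beyond the scatter). The count of hydrogen-bond donors is the same in both groups, so keeping that count does not by itself keep the number of compound 2. With 1-(2,3-dihydroxypropyl)-1H-1,2,3-triazol-4-yl in place of 4-(dimethylamino)butyl, the comparison gives a 1.9-fold lower number from compound 1 to compound 3 (0.27 log units; within the scatter), so these two side chains are not told apart in this assay. No measurement at hand bears on the reason for either step.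

Open, from the compounds shown here alone, is whether 2-hydroxyethyl or 2-aminoethyl on the same aromatic nitrogen would stand nearer compound 2 or compound 3 in this assay. Also open, going by these compounds, is how much of the step belongs to the ring of the departing group and how much to its defined stereocentres.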